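A Methoxyphenyl Swap on Compound 3, Expected to Change Little

The source may hold more compounds than are shown below. What is called first, only, known or untested is meant among the compounds shown, and "the series" means these compounds.

Measured in a functional assay on HOS-TE85 cells (Homo sapiens) for inhibition, read by CCK-8 assay, with a stated time of 72 h; a higher number here means a weaker inhibitor, a lower number a stronger inhibitor:
- compound 1 `COc1ccccc1N1C(=O)CSC1c1cccc(C(=O)NCCCCc2ccc(Cl)cc2)c1`: 78.6 nM
- compound 2 `COc1ccc(F)cc1N1C(=O)CSC1c1cccc(C(=O)NCCCCn2cccn2)c1`: 97.3 nM
- compound 3 `O=C(NCCCCn1cccn1)c1cccc(C2SCC(=O)N2c2cc(Br)ccn2)c1`: 105 nM

Compound 3 lies within the scatter of both compound 2 and compound 1, so these three values do not separate. The next compound is compound 4 `COc1ccccc1N1C(=O)CSC1c1cccc(C(=O)NCCCCn2cccn2)c1`, and the change is 2-methoxyphenyl in place of 4-bromopyridin-2-yl on an amide-type nitrogen in a ring. Among the measured compounds shown here, one measured step bears directly on this exchange. It is a 1.1-fold higher number from compound 2 to compound 3 (0.03 log units; within the scatter), in which 4-bromopyridin-2-yl took the place of 5-fluoro-2-methoxyphenyl at the same nitrogen, and it stayed within the scatter. Compound 1 also carries 2-methoxyphenyl there, with a different amide chain, and gives 78.6 nM. No step beyond the scatter is therefore expected in this assay, and no direction can be called with confidence. The estimated change is a 1.2-fold lower number from compound 3 to compound 4 (0.07 log units; within the scatter). Compound 4 is expected at 90 nM, with an estimated range from 45 nM to 180 nM.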

Compound 4, half-maximal inhibitory concentration: 91.7 nM
Estimate against measurement, compound 4: 1.0-fold (0.01 log units) below; measured number inside the range.
By their numbers in this assay, from the lowest: compounds 1, 4, 2 and 3 (each within the scatter of the next).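

In this assay the exchange of 4-bromopyridin-2-yl for 2-methoxyphenyl on the amide-type nitrogen now has a direct pair, and a 1.1-fold lower number from compound 3 to compound 4 (0.06 log units; within the scatter) stays within the scatter, as the step through 5-fluoro-2-methoxyphenyl did. Two further single changes also stay within the scatter: hydrogen in place of fluoro on an aromatic carbon gives a 1.1-fold lower number from compound 2 to compound 4 (0.03 log units; within the scatter) and 1H-pyrazol-1-yl in place of 4-chlorophenyl on the saturated chain gives a 1.2-fold higher number from compound 1 to compound 4 (0.07 log units; within the scatter) here. Nothing measured gives a reason why these exchanges leave the number within the scatter.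

All four compounds remain inseparable, so no group shown at either place sets a limit on what is tolerated. Going by these compounds, whether an amine or a carboxylic acid in place of 2-methoxyphenyl on that nitrogen, or a longer chain carrying the 1H-pyrazol-1-yl group, would move the number beyond the scatter remains open.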